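This account rests on a few compounds, and the source may have more. Where it says the series, first, only, none or still open, it means among the compounds named here.

Compound 3 `COc1cc(-c2ccnc3cc(-c4cccc(C#N)c4)nn23)cc(OC)c1OC` is one of three measured compounds on a shared core. In a functional assay on A549 cells (Homo sapiens) for inhibition, read by CCK-8 assay, with a stated time of 48 h (a higher number here means a weaker inhibitor, a lower number a stronger inhibitor), compound 3 gives > 10000 nM, which is a limit of the assay and not a number. Compound 1 `COc1cc(-c2ccnc3cc(-c4ccc(C(C)(C)C)cc4)nn23)cc(OC)c1OC` likewise gives a limit in this assay, > 10000 nM. Compound 2 `COc1ccc(-c2cc3nccc(-c4cc(OC)c(OC)c(OC)c4)n3n2)cc1` gives 376 nM in this assay. Compound 3 therefore sits at the limit of > 10000 nM in this assay, at which 2 of the 3 values shown sit. Compound 4 `COc1cc(-c2ccnc3cc(-c4ccc(C(F)(F)F)cc4)nn23)cc(OC)c1OC` carries 4-(trifluoromethyl)phenyl in place of 3-cyanophenyl on an aromatic carbon. The steps of an at least 26-fold higher number from compound 2 to compound 3 (1.42 log units; beyond the scatter) and a step that the two limits leave unreadable from compound 1 to compound 3 bear on this change, while an at least 26-fold lower number from compound 1 to compound 2 (1.42 log units; beyond the scatter) shows how far a methoxy-bearing phenyl moves away from the limit. Compound 1, carrying 4-(tert-butyl)phenyl, gives > 10000 nM, a limit. On that footing compound 4 is expected to remain near the limit, a step that the limit leaves unreadable from compound 3 to compound 4 expected to stay unreadable. Compound 4 is estimated at 12000 nM, between 3000 nM and 40000 nM.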

Compound 4, half-maximal inhibitory concentration: 2070 nM
Compound 4: middle estimate off by 5.8-fold (0.76 log units), on the high side; measured number outside the range, below it.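

A phenyl ring without a methoxy group can therefore move off the limit at this place on the five-membered aromatic ring, as two steps show: an at least 4.8-fold lower number from compound 3 to compound 4 (0.68 log units; beyond the scatter) and an at least 4.8-fold lower number from compound 1 to compound 4 (0.68 log units; beyond the scatter). Even so, 4-(trifluoromethyl)phenyl does not match 4-methoxyphenyl, with a 5.5-fold higher number from compound 2 to compound 4 (0.74 log units; beyond the scatter). Compound 1 and compound 3 remain at a limit of the assay, not a number: the limit of > 10000 nM in this assay, at which 2 of the 4 values shown sit.

The compounds shown leave open how a 4-aminophenyl or a 4-carboxyphenyl group would behave at this place, and whether either would stand nearer compound 2 or nearer the limit.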